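The compounds below may be only part of what the source reports. "The series", "measured", "known", "first", "only" and "open" are said of these compounds alone.

Compound 1 `CCC1=C(O)c2c(oc(-c3ccc(O)cc3)cc2=O)C(CC)(CC)C1=O` gives 20.6 uM in a functional assay on KB cells (Homo sapiens) for antiproliferative activity, read by sulforhodamine B assay, with a stated time of 3 days; on this read-out lower numbers stand for an effect already at smaller amounts and higher numbers for an effect only at larger amounts of compound. Compound 2 `CCC1=C(O)c2c(oc(-c3ccccc3C)cc2=O)C(CC)(CC)C1=O` gives 40.9 uM in this assay. For compound 3 `CCC1=C(O)c2c(oc(-c3ccccc3F)cc2=O)C(CC)(CC)C1=O` only a limit is known in this assay, namely > 56.2 uM.

Compound 3 therefore stands at the upper edge of what this assay reports (the limit of > 56.2 uM in this assay, at which 1 of the 3 values shown sits), so it needs larger amounts than the others to act. The step of an at least 2.7-fold higher number from compound 1 to compound 3 (0.43 log units; beyond the scatter) shows a real loss, while the step of an at least 1.3-fold higher number from compound 2 to compound 3 (0.13 log units; that floor lies within the scatter) is too small at its floor to be read. Compound 4 `CCC1=C(O)c2c(oc(-c3ccc(OC)c(Cl)c3)cc2=O)C(CC)(CC)C1=O` differs from compound 3 by 3-chloro-4-methoxyphenyl in place of 2-fluorophenyl on an aromatic carbon. Going by the values given here, the entering group brings a hydrogen-bond acceptor, which the 2-fluorophenyl of compound 3 lacks, and the only measured compound with an oxygen on that ring, compound 1, gives 20.6 uM. Among the compounds with values here, since the step of an at least 2.7-fold higher number from compound 1 to compound 3 (0.43 log units; beyond the scatter) went upward when that ring lost its oxygen, the return of an oxygen-bearing ring is expected to bring the number back down, though the added chloro has no precedent here. Compound 4 is therefore estimated at 30 uM, with a range from 10 uM to 80 uM. The expected step is an at least 1.8-fold lower number from compound 3 to compound 4 (0.27 log units; that floor lies within the scatter).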

Compound 4, concentration for half-maximal effect: 24.9 uM
Estimate against measurement, compound 4: 1.2-fold (0.08 log units) above, within the range that was stated.
By their numbers in this assay, from the lowest: compounds 1, 4 and 2 (each within the scatter of the next). At a limit, above all of these: compound 3.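

At this position, next to the ring oxygen, the change to 3-chloro-4-methoxyphenyl gives an at least 2.2-fold lower number from compound 3 to compound 4 (0.35 log units; beyond the scatter), so a ring with a methoxy oxygen and a chloro also stands clear of the 2-fluorophenyl compound. As far as these compounds go, compound 3 is known only as a limit, so the true size of that step stays unknown: the limit of > 56.2 uM in this assay, at which 1 of the 4 values shown sits. The other steps, a 1.6-fold lower number from compound 2 to compound 4 (0.22 log units; within the scatter) and a 1.2-fold higher number from compound 1 to compound 4 (0.08 log units; within the scatter), show that the free hydroxyl of compound 1 is not needed to reach this level, while compound 2, with no oxygen on that ring, goes against any simple rule that an oxygen is what counts.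

From the compounds shown here alone, compound 4 brings the chloro and the methoxy at once, and which of them matters remains open. Going by these compounds, how an amine or a carboxylic acid on that ring would read in this assay also remains open.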